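Swapping the aryl group on a fused bicyclic antagonist

The compounds below may be only part of what the source reports. "The series", "measured", "known", "first", "only" and "open" are said of these compounds alone.

Measured compounds:
- compound 1, `COc1ccc(-n2cnc3c(NC(C4CC4)C4CC4)nc(C)nc32)c(C)c1`: 47 nM
- compound 2, `COc1ccc(-n2c(C)nc3c(NC(C4CC4)C4CC4)nc(C)nc32)c(C)c1`: 14 nM
- compound 3, `COc1ccc(-n2c(C3CCCO3)nc3c(NC(C4CC4)C4CC4)nc(C)nc32)cc1`: 867 nM

All three were tested in a functional assay on CHO cells for antagonist activity at corticotropin-releasing factor receptor 1 (Homo sapiens), read by cAMP accumulation; a higher number here means a weaker inhibitor, a lower number a stronger inhibitor. For the measured compounds named here, compound 2 stands lowest of the three numbers; compound 1 is nearest, and the only single-point step between measured compounds is a 3.4-fold lower number from compound 1 to compound 2 (0.53 log units; beyond the scatter), a methyl added to an aromatic carbon of the shared core. Going by the values given here, compound 3, which differs from compound 2 in two places at once, gives a far higher number, so no step can be assigned to either change alone.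

Compound 4, `Cc1nc(NC(C2CC2)C2CC2)c2nc(C)n(-c3ccc(Cl)cc3)c2n1`, arises from compound 2 by 4-chlorophenyl in place of 4-methoxy-2-methylphenyl on an aromatic nitrogen. Among the compounds with values here, no measured step touches this aryl group, so the only guidance is indirect: compound 3, which also lacks the 2-methyl on its aryl ring, is much weaker than compound 2, though it carries a second change too. An increase in the number is therefore expected, of moderate size, with wide uncertainty; the estimated step is a 5.7-fold higher number from compound 2 to compound 4 (0.76 log units; beyond the scatter). For compound 4 the expected value is 80 nM (range 20 nM to 400 nM).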

Compound 4, inhibition constant: 11 nM
For compound 4 the middle estimate is 7.3-fold (0.86 log units) above the measured one; the measured number lies below the stated range.
By their numbers in this assay, from the lowest: compounds 4 and 2 (each within the scatter of the next); then compound 1; then compound 3.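

In this assay, 4-chlorophenyl in place of 4-methoxy-2-methylphenyl on the aromatic nitrogen gives a 1.3-fold lower number from compound 2 to compound 4 (0.10 log units; within the scatter), so the two compounds cannot be told apart. For the compounds shown here, this is the first step that can be read at this aryl group, and it shows that the group can lose both its methoxy and its methyl and gain a chlorine while the number stays within the scatter. Nothing measured here explains why these two aryl groups give matching numbers.

Several features change together in this one step, so what the methoxy, the methyl and the chlorine each contribute on its own stays open, and their separate contributions could be large but offsetting, or small. As far as these compounds go, it is also open how this assay would respond to an amine, a carboxylic acid or a longer chain on the aryl ring.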